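The compounds below may be only part of what the source reports. "The series", "measured", "known", "first", "only" and "open" are said of these compounds alone.

Measured compounds in an ADME assay on microsomes from liver (Homo sapiens) for metabolic stability, read by LC-MS, with a stated time of 10 min; a higher number here means that more of the compound is left, a lower number that less of the compound is left:
- compound 1, `CN(C[C@H]1Cc2c(cccc2N2C[C@@H]3C[C@H]2CN3)CN1)[C@H]1CCCc2cccnc21`, gives 100%
- compound 2, `Cc1cnc2c(c1)CCC[C@@H]2N(C)C[C@H]1Cc2c(cccc2N2CCNCC2)CN1`, gives 47.8%
- compound 3, `FC1(F)CCC(CN(C[C@H]2Cc3c(cccc3N3CCNCC3)CN2)[C@H]2CCCc3cccnc32)CC1`, gives 68.6%

Compound 1 stands highest of the three numbers in this assay. The nearest of the others is compound 3, which lies lower by a margin beyond the usual scatter; compound 2 lies lower still, also beyond the scatter. Among the measured compounds shown here, compounds 2 and 3 each differ from compound 1 in more than one place, so no single-change step between measured compounds is available in this set.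

The next compound, compound 4, `CN1CCN(c2cccc3c2C[C@H](CN(C)[C@H]2CCCc4cccnc42)NC3)CC1`, is to be measured in this assay. It differs from compound 1 in one place: a group of 7 heavy atoms (5 carbon, 2 nitrogen; one six-membered non-aromatic ring with 2 hetero atoms) in place of a group of 7 heavy atoms (5 carbon, 2 nitrogen; 2 five-membered non-aromatic rings with 1 hetero atom each), on an aromatic carbon

For the measured compounds named here, no measured pair shows this change on its own, so its effect in this assay is not known from the series. Given that compound 1 sits at the top of the range in this assay with 100%, and that the two other measured compounds fall well below it, the step from compound 1 to compound 4 is expected to be downward and beyond the scatter, a number 30 percentage points lower from compound 1 to compound 4 (beyond the scatter). Compound 4 is therefore estimated at 70% in this assay, with a likely range from 45% to 95%.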

Compound 4, percent of the compound remaining: 75.8%
Estimate against measurement, compound 4: 5.8 percentage points below, within the range that was stated.
By their numbers in this assay, from the lowest: compound 2; then compounds 3 and 4 (each within the scatter of the next); then compound 1.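

Among the compounds shown here, the first single-place comparison now exists at this aromatic carbon of the six-membered aromatic ring of carbon only. In this assay, 4-methylpiperazin-1-yl in place of the group with 2 five-membered non-aromatic rings with 1 hetero atom each gives a number 24.2 percentage points lower from compound 1 to compound 4 (beyond the scatter), so the read-out at this position responds to the identity of the group even though both groups have 7 heavy atoms, 5 carbon and 2 nitrogen. What does differ in the counts is the hydrogen-bond donors, 1 in the group that leaves and 0 in 4-methylpiperazin-1-yl, and the defined stereocentres, 2 against none, but nothing measured here links the step to either difference or to any other feature.

From the compounds shown here alone, with one pair, it remains open which feature of the two groups carries the step, and whether it would be of similar size on a core differing elsewhere. Going by these compounds, it is also open where a morpholin-4-yl or a dimethylamino group on the same aromatic carbon would fall relative to compound 1 and compound 4 in this assay on the otherwise unchanged structure.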